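This account rests on a few compounds, and the source may have more. Where it says the series, first, only, none or still open, it means among the compounds named here.

Compounds measured so far: compound 1 `CCCCCCCCCCCCCCNC(=O)[C@@H](NC(=O)c1nccc2ccccc12)[C@@H](C)O` gives 21600 nM; compound 2 `CCCCCCCCCCCCCCCCCCNC(=O)[C@@H](NC(=O)c1cccs1)[C@@H](C)O` gives 117000 nM. Compound 3 `CCCCCCCCCCCCCCCCCCNC(=O)[C@@H](NC(=O)c1cc2ccccc2o1)[C@@H](C)O` gives only a limit of the assay, > 200000 nM, in a functional assay on SiHa cells (Homo sapiens) for cytotoxicity, read by MTT assay, with a stated time of 48 h; on this read-out lower numbers stand for stronger inhibition and higher numbers for weaker inhibition; one of the three values sits at that limit (the limit of > 200000 nM in this assay, at which 1 of the 3 values shown sits).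

Compound 4 `CCCCCCCCCCCCCCCCCCNC(=O)[C@@H](NC(=O)c1nccc2ccccc12)[C@@H](C)O` differs from compound 3 by isoquinolin-1-yl in place of 1-benzofuran-2-yl on a carbonyl carbon. Within the data shown here, the only measured step on this carbonyl carbon is an at least 1.7-fold higher number from compound 2 to compound 3 (0.23 log units; that floor lies within the scatter), whose floor lies within the scatter and which ends at a limit, so it gives no direction for a further swap of the heteroaryl group. Compound 1, which carries isoquinolin-1-yl on a shorter chain, shows a lower number than compound 2 or compound 3. The step of an at least 3.3-fold lower number from compound 3 to compound 4 (0.52 log units; beyond the scatter) is therefore expected to bring a lower number. Compound 4 is estimated at 60000 nM, within 15000 nM to 200000 nM.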

Compound 4, half-maximal inhibitory concentration: 51200 nM
Beside the measured number, compound 4's estimate is 1.2-fold (0.07 log units) above it; the range from low to high includes it.
By their numbers in this assay, from the lowest: compound 1; then compound 4; then compound 2. At a limit, above all of these: compound 3.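

In this assay, isoquinolin-1-yl on the carbonyl carbon lowers the number beyond the scatter against thiophen-2-yl (a 2.3-fold lower number from compound 2 to compound 4 (0.36 log units; beyond the scatter)) and against 1-benzofuran-2-yl (an at least 3.9-fold lower number from compound 3 to compound 4 (0.59 log units; beyond the scatter)), so this position now shows a clear dependence on the heteroaryl group. The second of these steps is only a floor, since compound 3 stands at a limit of the assay: the limit of > 200000 nM in this assay, at which 1 of the 4 values shown sits. With isoquinolin-1-yl held fixed, butyl in place of hydrogen on the chain raises the number (a 2.4-fold higher number from compound 1 to compound 4 (0.37 log units; beyond the scatter)), so chain length counts as well.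

The compounds shown leave open whether pyridin-2-yl or quinolin-2-yl on the carbonyl carbon would keep this gain. They also leave open how a shorter chain, or a chain ending in an amine, would read.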